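Amide amine swap on a longer alkoxy chain

The source may hold more compounds than are shown below. What is called first, only, known or untested is meant among the compounds shown, and "the series" means these compounds.

Compound 1, `CCCCN(C)C(=O)CCCOc1cc(OC)c(OC)c2oc(-c3ccc(OC)cc3)c(O)c(=O)c12`: in a functional assay on A549 cells (Homo sapiens) for antiproliferative activity, read by sulforhodamine B assay, with a stated time of 48 h (a lower number here means a stronger inhibitor, a higher number a weaker inhibitor), compound 1 gives > 40000 nM, which is a limit of the assay.
Compound 2, `COc1ccc(-c2oc3c(OC)c(OC)cc(OCCCC(=O)NCc4ccccn4)c3c(=O)c2O)cc1`: in this assay compound 2 gives > 40000 nM, likewise a limit.
Among the compounds with values here, compound 3, `CCCCN(C)C(=O)CCCCOc1cc(OC)c(OC)c2oc(-c3ccc(OC)cc3)c(O)c(=O)c12`: in this assay compound 3 gives 16700 nM, the only number in the set.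

The change from compound 1 to compound 2 is ((pyridin-2-yl)methyl)amino in place of butyl(methyl)amino on a carbonyl carbon. Its step is a step that the two limits leave unreadable from compound 1 to compound 2, because the limit of > 40000 nM in this assay, at which 2 of the 3 values shown sit, covers both values. The cores of compound 1 and compound 3 differ by (butyl(methyl)carbamoyl)methyl in place of butyl(methyl)carbamoyl on a saturated chain carbon, three bonds along the chain from an oxygen on an aromatic ring; that step is an at least 2.3-fold lower number from compound 1 to compound 3 (0.37 log units; beyond the scatter), and the matching step is an at least 2.3-fold lower number from compound 2 to compound 3 (0.37 log units; beyond the scatter).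

Compound 4, `COc1ccc(-c2oc3c(OC)c(OC)cc(OCCCCC(=O)NCc4ccccn4)c3c(=O)c2O)cc1`, is not yet measured. It differs from compound 3 by ((pyridin-2-yl)methyl)amino in place of butyl(methyl)amino on a carbonyl carbon, at the same place as in the earlier pair, so this is the same change. In this assay the step from compound 3 to compound 4 is expected to be a 1.5-fold higher number from compound 3 to compound 4 (0.18 log units; within the scatter), set beside the earlier one, which gives no readable size; the expectation therefore rests only on compound 3 and its value 16700 nM. Compound 4 is estimated at 25000 nM, with a range from 8000 nM to 60000 nM.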

Compound 4, half-maximal inhibitory concentration: > 40000 nM
Compound 4 gave a limit, no number (the forecaster's own chance of this, stated with the estimate: 40%); middle value at least 1.6-fold (0.20 log units) from the limit.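

In this assay, ((pyridin-2-yl)methyl)amino in place of butyl(methyl)amino on the core of compound 3 gives an at least 2.3-fold higher number from compound 3 to compound 4 (0.37 log units; beyond the scatter). On these data alone, compound 4 gives > 40000 nM, a limit, so the full size of this step stays unknown. The same change on the core of compound 1 cannot be read, nor can the steps from compound 1 and compound 2 to compound 4, so a loss is shown on one core only and carrying the change from one core to another remains untested.

As far as these compounds go, only compound 3 gives a number, which leaves no second measured size for this change on either core: the limit of > 40000 nM in this assay, at which 3 of the 4 values shown sit. Still open is whether butylamino on the carbonyl carbon, a carboxylic acid in place of the amide, or a longer chain would give a readable value in this assay.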